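Notes on the shared core: the change from compound 2 to compound 4

The source may report more compounds than this note shows. Statements on the series, on what has been measured and on what is new or still open speak of the compounds shown alone.

Of the compounds shown here, three have been measured in an ADME assay on MDBK cells (Bos taurus) for cytotoxicity; on this read-out higher numbers stand for lower toxicity in this test and lower numbers for higher toxicity in this test. Compound 1 `Fc1cccc(F)c1-c1nc2ccn(Cc3ccccc3)cc-2n1` is reported only as a limit of the assay, > 100000 nM. Compound 2 `Clc1cccc(Cn2ccc3nc(-c4ccccc4)nc-3c2)c1` likewise gives only a limit, > 100000 nM, so its position on this read-out is known only as a floor and not as a number. Compound 3 `FC(F)(F)c1cccc(Cn2ccc3nc(-c4ccccc4)nc-3c2)c1` gives 98000 nM. For the measured compounds named here, the single step between measured neighbours, trifluoromethyl in place of chloro on an aromatic carbon, amounts to an at least 1.0-fold lower number from compound 2 to compound 3 (0.00 log units; that floor lies within the scatter); it reads as no change, which follows from the limit of > 100000 nM in this assay, at which 2 of the 3 values shown sit.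

Compound 4 `CC(C)N(CCn1ccc2nc(-c3ccccc3)nc-2c1)C(C)C` differs from compound 2 as follows: (diisopropylamino)methyl in place of 3-chlorophenyl on a saturated chain carbon bound to an aromatic nitrogen

Going by the values given here, no measured step swaps an aromatic substituent for a chain group of this kind, so the step from compound 2 to compound 3 is the only comparison available, and it sits at the floor. The expected step is therefore a number no higher from compound 2 to compound 4 (the limit leaves the size open), that is, none beyond the scatter. Compound 4 is estimated to give 100000 nM in this assay, with a range from 30000 nM to 300000 nM, and a substantial chance that only a limit is again reported.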

Compound 4, half-maximal cytotoxic concentration: > 100000 nM
Compound 4 was reported as a limit (the forecaster's own chance of this, stated with the estimate: 55%); the middle value sits exactly at the limit.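

Compound 2 and compound 4 are both reported only as limits in this assay, so no step between them can be read: the limit of > 100000 nM in this assay, at which 3 of the 4 values shown sit.

The compounds shown leave open whether (diisopropylamino)methyl in place of 3-chlorophenyl shifts this read-out at all, and in which direction, with compound 3 the only one carrying a number.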